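The source may hold more compounds than are shown below. What is called first, only, known or untested is meant among the compounds shown, and "the series" means these compounds.

In a functional assay on A549 cells (Homo sapiens) for antiproliferative activity, read by MTT assay, with a stated time of 48 h (a lower number here means a stronger inhibitor, a higher number a weaker inhibitor), compound 1 `CC(C)=CCC[C@]1(C)/C=C/[C@@H](OC(=O)C=C(C)C)[C@](C)(O)/C=C/[C@H](O)/C(CO)=C\C1` gives > 40000 nM as a limit of the assay and not a number. Among the compounds with values here, compound 2 `CO[C@@H]1/C=C/[C@@](C)(O)[C@H](OC(=O)C=C(C)C)/C=C/[C@@](C)(CCC=C(C)C)C/C=C\1CO` gives 11200 nM as the only actual number so far. Compound 3 `CO[C@H]1/C=C/[C@@](C)(O)[C@H](OC(=O)C=C(C)C)/C=C/[C@@](C)(CCC=C(C)C)C/C=C\1CO` has the same atoms and bonds as compound 2, and the change is the two compounds have the same atoms and bonds and differ only in configuration as drawn: 1 of 7 stereo elements differ; a stereocentre at a saturated ring carbon is drawn R in compound 2 and S in compound 3 in configuration alone: a stereocentre at a saturated ring carbon is drawn R in compound 2 and S in compound 3. Within the data shown here, no measured pair tests such a change, so in this assay no step beyond the scatter is expected, and no direction is favoured. The estimated change is a 1.1-fold higher number from compound 2 to compound 3 (0.03 log units; within the scatter) and no more. Compound 3 is expected at 12000 nM with an estimated range of 5000 nM to 30000 nM in this assay.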

Compound 3, half-maximal inhibitory concentration: 19200 nM
For compound 3 the middle estimate is 1.6-fold (0.20 log units) below the measured one; low and high end bracket the measured number.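

In this assay, the drawn configuration at this saturated ring carbon gets its first test, giving a 1.7-fold higher number from compound 2 to compound 3 (0.23 log units; within the scatter), so the two drawings are not separated at this position. Methyl in place of hydrogen on an oxygen on a saturated carbon gives an at least 2.0-fold lower number from compound 1 to compound 3 (0.31 log units; beyond the scatter). Compound 1 stands at a limit of the assay, so this step has only one firm end: the limit of > 40000 nM in this assay, at which 1 of the 3 values shown sits.

The compounds shown leave open whether an ethyl ether, an acetate ester or an amine at this position would read differently from the methyl ether. They also leave open how large the step from the free hydroxyl truly is.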